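The source may hold more compounds than are shown below. What is called first, only, known or untested is meant among the compounds shown, and "the series" means these compounds.

In a functional assay on WiDr cells (Homo sapiens) for inhibition, read by sulforhodamine B assay, with a stated time of 48 h (on this read-out lower numbers stand for stronger inhibition of growth and higher numbers for weaker inhibition of growth), the three measured compounds stand as follows:

Compound 1, `O=C(/C(=C/c1ccccc1)CCl)c1ccccc1`: 18000 nM
Compound 2, `O=C(/C(=C/c1ccc(Cl)cc1)CCl)c1ccccc1`: 19000 nM
Compound 3, `CC(=O)OC/C(=C\c1ccccc1)C(=O)c1ccccc1`: 17000 nM

All three numbers lie close together. Compound 2 differs from compound 1 by chloro in place of hydrogen on an aromatic carbon, and this change gave a 1.1-fold higher number from compound 1 to compound 2 (0.02 log units; within the scatter). Compound 3 differs from compound 1 by acetoxy in place of chloro on a saturated chain carbon bound to a double-bonded chain carbon, which gave a 1.1-fold lower number from compound 1 to compound 3 (0.02 log units; within the scatter). Neither change moved the number beyond the usual scatter of this kind of measurement.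

Compound 4, `CC(=O)OC/C(=C\c1ccc(Cl)cc1)C(=O)c1ccccc1`, has not yet been measured in this assay. It differs from compound 3 by chloro in place of hydrogen on an aromatic carbon, the same change that was made from compound 1 to compound 2, at the same place on the ring. The two cores differ by acetoxy in place of chloro on a saturated chain carbon bound to a double-bonded chain carbon.

Since that change left the number essentially unchanged from compound 1 to compound 2, as a 1.1-fold higher number from compound 1 to compound 2 (0.02 log units; within the scatter) shows, compound 4 is expected to behave like compound 3. Compound 4 is estimated at 18000 nM, within a range from 9000 nM to 36000 nM. This estimate amounts to a 1.1-fold higher number from compound 3 to compound 4 (0.02 log units; within the scatter), resting on the observed 1.1-fold higher number from compound 1 to compound 2 (0.02 log units; within the scatter).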

Compound 4, concentration for 50% growth inhibition: 4800 nM
Compound 4: middle estimate off by 3.8-fold (0.57 log units), on the high side; the measured number lies below the stated range.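

In this assay, chloro in place of hydrogen on an aromatic carbon gave a 3.5-fold lower number from compound 3 to compound 4 (0.55 log units; beyond the scatter), so the step seen on the core of compound 1 did not carry over to the core of compound 3: the same change on two cores in this assay, a 1.1-fold higher number (0.02 log units; within the scatter) from compound 1 to compound 2 and a 3.5-fold lower number (0.55 log units; beyond the scatter) from compound 3 to compound 4, 3.7-fold (0.57 log units) apart, beyond the scatter of two such steps Read the other way round, acetoxy in place of chloro on the saturated chain carbon gave a 4.0-fold lower number from compound 2 to compound 4 (0.60 log units; beyond the scatter), and this step also parted from its earlier counterpart: the same change on two cores in this assay, a 1.1-fold lower number (0.02 log units; within the scatter) from compound 1 to compound 3 and a 4.0-fold lower number (0.60 log units; beyond the scatter) from compound 2 to compound 4, 3.7-fold (0.57 log units) apart, beyond the scatter of two such steps These four compounds show that the two changes did not add up independently here, as the step from phenyl to 4-chlorophenyl differed with the group on the chain, but a single set of four compounds does not show why this happened or whether it holds elsewhere in the series.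

The compounds shown leave open whether bromo, fluoro or methoxy in place of the chloro on the ring would follow the same course. They also leave open whether a longer ester chain or an amine in place of the acetoxy would do so.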